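Swapping Methoxy for Trifluoromethyl on the Aromatic Ring

The compounds below may be only part of what the source reports. "The series", "measured", "known", "first", "only" and "open" are said of these compounds alone.

Measured so far in a physicochemical assay for solubility, read by LC-MS, at pH 6.8; a higher number here means a more soluble compound, a lower number a less soluble compound:
- Compound 1 `CN(Cc1cc(C(F)(F)F)cc(C(F)(F)F)c1)C(=O)c1c(OCCCC2CCN(C(=O)OC3(C)CC3)CC2)c2cccnc2n(C)c1=O`: < 0.3 ug/mL
- Compound 2 `COc1cc(CN(C)C(=O)c2c(OCCCC3CCN(C(=O)OC4(C)CC4)CC3)c3cccnc3n(C)c2=O)cc(OC)c1`: 16 ug/mL

The reading for compound 1 is a limit of the assay, not a number. Among the measured compounds shown here, compound 2, at 16 ug/mL, holds the only actual number so far. Compound 3 `COc1cc(CN(C)C(=O)c2c(OCCCC3CCN(C(=O)OC4(C)CC4)CC3)c3cccnc3n(C)c2=O)cc(C(F)(F)F)c1` differs from compound 2 by trifluoromethyl in place of methoxy on an aromatic carbon, or 3,5-dimethoxyphenyl to 3-methoxy-5-(trifluoromethyl)phenyl. For the measured compounds named here, no measured step exists to guide this change, so the expectation leans on the two readings alone. The expected step is an 8.0-fold lower number from compound 2 to compound 3 (0.90 log units; beyond the scatter), downward and beyond the usual scatter. For compound 3 the estimate in this assay is 2 ug/mL, with an expected range of 0.4 ug/mL to 8 ug/mL.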

Compound 3, solubility: 0.79 ug/mL
Estimate against measurement, compound 3: 2.5-fold (0.40 log units) above; low and high end bracket the measured number.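

In this assay, among the compounds shown here, the first measured step at this position is large: a 20-fold lower number from compound 2 to compound 3 (1.31 log units; beyond the scatter) when trifluoromethyl replaces a single methoxy on the aromatic ring. Putting methoxy in place of trifluoromethyl at the other position gives an at least 2.6-fold higher number from compound 1 to compound 3 (0.42 log units; beyond the scatter) as a second, smaller-bounded step along the same series. The reading for compound 1 is a limit of the assay, so that step has only a lower bound: the limit of < 0.3 ug/mL in this assay, at which 1 of the 3 values shown sits.

The compounds shown leave open how an amine or a carboxylic acid at this position would read.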